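Taking the oxan-2-yl group off compound 3

This account rests on a few compounds, and the source may have more. Where it says the series, first, only, none or still open, it means among the compounds named here.

Measured in an ADME assay for pharmacokinetics, read by HPLC; a lower number here means that the compound disappears faster, a higher number that the compound lasts longer:
- compound 1 `COCO[C@@H]1/C=C(\C)CC[C@]2([C@@](C)(O)C(=O)SCc3oc(=O)oc3C)CC(=O)N([C@H](C)c3nc(cs3)/C=C/C=C/C1=O)[S+]2[O-]`: 24 h
- compound 2 `C/C1=C\[C@@H](O)C(=O)/C=C/C=C/c2csc(n2)[C@@H](C)N2C(=O)C[C@@]([C@@](C)(O)C(=O)SCC(=O)OC(C)(C)C)(CC1)[S+]2[O-]`: > 24 h
- compound 3 `C/C1=C\[C@@H](O[C@@H]2CCCCO2)C(=O)/C=C/C=C/c2csc(n2)[C@@H](C)N2C(=O)C[C@@]([C@@](C)(O)C(=O)SCc3oc(=O)oc3C)(CC1)[S+]2[O-]`: 30 h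

In this assay compound 3 gives 30 h, which lies within the scatter of compound 1 at 24 h. Compound 2 gives > 24 h, and this is a limit of the assay and not a number.

Compound 4 `C/C1=C\[C@@H](O)C(=O)/C=C/C=C/c2csc(n2)[C@@H](C)N2C(=O)C[C@@]([C@@](C)(O)C(=O)SCc3oc(=O)oc3C)(CC1)[S+]2[O-]` has not yet been measured. It differs from compound 3 by hydrogen in place of oxan-2-yl on an oxygen on a saturated carbon. Cut one bond further out, the same difference reads (oxan-2-yl)oxy to hydroxy.

Within the data shown here, only one measured step bears on this oxygen, and it is a 1.3-fold higher number from compound 1 to compound 3 (0.10 log units; within the scatter), with oxan-2-yl in place of methoxymethyl. That step exchanged one group for another and did not leave a free hydroxy, so it is indirect evidence for the present change. It gives no reason to expect a shift beyond the scatter in this assay, in either direction. The expected step is a 1.2-fold lower number from compound 3 to compound 4 (0.06 log units; within the scatter), which amounts to no change beyond the scatter. Compound 4 is estimated at 26 h, with an expected range from 14 h to 50 h.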

Compound 4, half-life: 16 h
Compound 4: the middle estimate sits 1.6-fold (0.21 log units) above what was measured; the measured number falls inside the stated range.
By their numbers in this assay, from the lowest: compounds 4, 1 and 3 (each within the scatter of the next).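

In this assay, the change on this oxygen can now be read directly: hydrogen in place of oxan-2-yl gives a 1.9-fold lower number from compound 3 to compound 4 (0.27 log units; within the scatter) and hydrogen in place of methoxymethyl gives a 1.5-fold lower number from compound 1 to compound 4 (0.18 log units; within the scatter), so neither step to the free hydroxy goes beyond the scatter, whereas the earlier step only exchanged one group for another. Compound 2 gives > 24 h, which is a limit of the assay and not a number: the limit of > 24 h in this assay, at which 1 of the 4 values shown sits. With the hydroxy kept, the group on the saturated chain carbon bound to a sulfur can therefore be read only as a floor, an at least 1.5-fold lower number from compound 2 to compound 4 (0.17 log units; that floor lies within the scatter), and this says nothing firm about how far the two groups at that place lie apart.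

From the compounds shown here alone, it remains open whether a methyl or an acetyl group on this oxygen, or an amine in place of the hydroxy, would move the half-life beyond the scatter. Going by these compounds, it is also open whether a longer chain or a carboxylic acid at the saturated chain carbon bound to a sulfur would do so.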